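The source may hold more compounds than are shown below. What is called first, only, known or untested is meant among the compounds shown, and "the series" means these compounds.

Compound 1 `COc1cc(-c2ccnc3cc(-c4cccc(C#N)c4)nn23)cc(OC)c1OC`: > 10000 nM (a limit)
Compound 2 `COc1cc(-c2ccnc3cc(-c4ccc5cc[nH]c5c4)nn23)cc(OC)c1OC`: 23 nM
Compound 3 `C=Cc1ccc(-c2cc3nccc(-c4cc(OC)c(OC)c(OC)c4)n3n2)cc1`: 193 nM

In a functional assay on MCF7 cells (Homo sapiens) for inhibition, read by CCK-8 assay, with a stated time of 48 h (a lower number here means a stronger inhibitor, a higher number a weaker inhibitor), compound 3 gives 193 nM, the higher of the two actual numbers. Compound 1 reads > 10000 nM, which is a limit of the assay and not a number. The nearest neighbour of compound 3 is compound 2, with an 8.4-fold higher number from compound 2 to compound 3 (0.92 log units; beyond the scatter).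

Compound 4 `COc1cc(-c2ccnc3cc(-c4ccc5cnn(C)c5c4)nn23)cc(OC)c1OC` carries 1-methyl-1H-indazol-6-yl in place of 4-vinylphenyl on an aromatic carbon. Three measured steps change this same place. Two are large, an at least 430-fold lower number from compound 1 to compound 2 (2.63 log units; beyond the scatter) and an at least 51-fold lower number from compound 1 to compound 3 (1.71 log units; beyond the scatter), so the number in this assay responds strongly to the group here. The modest step is the closest guide, since the entering group resembles the 1H-indol-6-yl of compound 2, and that compound shows an 8.4-fold higher number from compound 2 to compound 3 (0.92 log units; beyond the scatter). The methyl-bearing group is still a different one, so a modest drop is expected rather than the full gap. The expected change is a 3.2-fold lower number from compound 3 to compound 4 (0.51 log units; beyond the scatter). For compound 4 the estimate is 60 nM, with an expected range of 15 nM to 400 nM.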

Compound 4, half-maximal inhibitory concentration: 279 nM
Compound 4: the middle estimate sits 4.7-fold (0.67 log units) below what was measured; measured number inside the range.
By their numbers in this assay, from the lowest: compound 2; then compounds 3 and 4 (each within the scatter of the next). At a limit, above all of these: compound 1.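

In this assay, a fused two-ring group at this aromatic carbon is not enough to keep the low number of compound 2, as 1-methyl-1H-indazol-6-yl gives a 12-fold higher number from compound 2 to compound 4 (1.08 log units; beyond the scatter). The same group cannot be told apart from the single-ring 4-vinylphenyl, with a 1.4-fold higher number from compound 3 to compound 4 (0.16 log units; within the scatter), so among these compounds the 1H-indol-6-yl of compound 2 stands apart from both. The step of an at least 35-fold lower number from compound 1 to compound 4 (1.55 log units; beyond the scatter) confirms that this group still differs clearly from 3-cyanophenyl, although compound 1 marks only a limit and not a number: the limit of > 10000 nM in this assay, at which 1 of the 4 values shown sits.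

Compound 2 and compound 4 differ both in the ring nitrogen and in the methyl, so the compounds shown do not separate the two changes. A plain 1H-indazol-6-yl or a 1-methyl-1H-indol-6-yl at this position would be needed to divide that gap.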